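Methoxy added to a chalcone ring: an expected gain

This account rests on a few compounds, and the source may have more. Where it says the series, first, only, none or still open, it means among the compounds named here.

Compound 1 `COc1ccc(/C=C/C(=O)c2c(OC)cc(O)c(CC=C(C)C)c2O)cc1` and compound 2 `COc1ccc(/C=C/C(=O)c2c(OC)cc(O)c(CC=C(C)C)c2O)cc1OC` share a core, and in a functional assay on A549 cells (Homo sapiens) for inhibition, read by MTT assay, with a stated time of 72 h (a higher number here means a weaker inhibitor, a lower number a stronger inhibitor), compound 1 gives 38000 nM while compound 2 gives 15700 nM. The only difference between them is methoxy in place of hydrogen on an aromatic carbon, and it made a 2.4-fold lower number from compound 1 to compound 2 (0.38 log units; beyond the scatter). Compound 3 `COc1cc(/C=C/C(=O)c2c(OC)cc(OC)cc2OC)cc(OC)c1` has a different core; the difference between the core of compound 3 and that of compound 1 is not broken down here. In this assay compound 3 gives 10100 nM, the lowest of the three numbers, though its gap to compound 2 lies within the scatter.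

Compound 4 `COc1cc(OC)c(C(=O)/C=C/c2cc(OC)c(OC)c(OC)c2)c(OC)c1` is not yet measured. It differs from compound 3 by methoxy in place of hydrogen on an aromatic carbon. Among the measured compounds shown here, this is the same kind of change as the one from compound 1 to compound 2, but the surroundings differ: there the entering group sat ortho to a methoxy group and meta to a large group, here it sits ortho to two methoxy groups and para to a large group. Resting on the step from compound 1 to compound 2, compound 4 is expected to show a 2.9-fold lower number from compound 3 to compound 4 (0.46 log units; beyond the scatter) in this assay. The estimate for compound 4 is 3500 nM, with a likely range from 900 nM to 13000 nM.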

Compound 4, half-maximal inhibitory concentration: 22300 nM
The estimate for compound 4 lay 6.4-fold (0.80 log units) below the measured number, outside the stated range (above it).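

In this assay the added methoxy did not repeat its earlier direction: it gave a 2.2-fold higher number from compound 3 to compound 4 (0.34 log units; beyond the scatter), so the change that lowered the number on the core of compound 1 raised it on the core of compound 3. The two steps point opposite ways, and the gap between them is too large to be scatter: the same change on two cores in this assay, a 2.4-fold lower number (0.38 log units; beyond the scatter) from compound 1 to compound 2 and a 2.2-fold higher number (0.34 log units; beyond the scatter) from compound 3 to compound 4, 5.3-fold (0.73 log units) apart, beyond the scatter of two such steps. This shows that the effect of this change did not carry from one of these cores to the other, but with a single pair on each core it does not show whether the core itself or the place of entry sets the difference, since the surroundings of the entering group also differ.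

On these data alone, it remains open whether an ethoxy group or a chlorine atom at the same place would follow the methoxy on each core. Also open, as far as these compounds go, is which direction the same methoxy step would take on a third core.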